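The compounds below may be only part of what the source reports. "The series", "measured", "known", "first", "only" and "open" are said of these compounds alone.

In an ADME assay on HEK-293T cells (Homo sapiens) for cytotoxicity, read by MTT assay, with a stated time of 24 h (on this read-out lower numbers stand for higher toxicity in this test and higher numbers for lower toxicity in this test), three compounds have been measured: compound 1 `Cc1ccc(C(=O)n2c(-c3cn(-c4ccccc4)nc3-c3ccc(C(F)(F)F)cc3)nc3ccccc32)cc1` gives 169000 nM; compound 2 `Cc1ccc(C(=O)n2c(-c3cn(-c4ccccc4)nc3-c3ccc(C(F)(F)F)cc3)nc3ccccc32)cn1` gives 153000 nM; compound 3 `Cc1ccc(C(=O)n2c(-c3cn(-c4ccccc4)nc3-c3ccc(C)cc3)nc3ccccc32)cc1` gives 176000 nM.

Compound 2 differs from compound 1 by 6-methylpyridin-3-yl in place of 4-methylphenyl on a carbonyl carbon. This change gave a 1.1-fold lower number from compound 1 to compound 2 (0.04 log units; within the scatter). The core of compound 3 differs from the core of compound 1 by methyl in place of trifluoromethyl on an aromatic carbon, and that change gave a 1.0-fold higher number from compound 1 to compound 3 (0.02 log units; within the scatter). Within the data shown here, all three values thus sit within the usual scatter of one another, and no compound can be called more or less toxic than another in this assay.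

Compound 4 `Cc1ccc(-c2nn(-c3ccccc3)cc2-c2nc3ccccc3n2C(=O)c2ccc(C)nc2)cc1` is not yet measured. It differs from compound 3 by 6-methylpyridin-3-yl in place of 4-methylphenyl on a carbonyl carbon, the same change as that from compound 1 to compound 2, made on the other core. The step from compound 3 to compound 4 in this assay is expected to be a 1.1-fold lower number from compound 3 to compound 4 (0.04 log units; within the scatter), resting on the step of a 1.1-fold lower number from compound 1 to compound 2 (0.04 log units; within the scatter) observed on the core of compound 1. For compound 4 the estimate in this assay is 160000 nM, with a range from 110000 nM to 230000 nM.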

Compound 4, half-maximal cytotoxic concentration: 145000 nM
The estimate for compound 4 lay 1.1-fold (0.04 log units) above the measured number; the measured number falls inside the stated range.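

In this assay, 6-methylpyridin-3-yl in place of 4-methylphenyl on a carbonyl carbon gave a 1.2-fold lower number from compound 3 to compound 4 (0.08 log units; within the scatter), and this step agrees with the earlier one on the other core: the same change on two cores in this assay, a 1.1-fold lower number (0.04 log units; within the scatter) from compound 1 to compound 2 and a 1.2-fold lower number (0.08 log units; within the scatter) from compound 3 to compound 4, 1.1-fold (0.04 log units) apart, within the scatter of two such steps. Methyl in place of trifluoromethyl on an aromatic carbon gave a 1.1-fold lower number from compound 2 to compound 4 (0.02 log units; within the scatter), and this step likewise agrees with its earlier counterpart: the same change on two cores in this assay, a 1.0-fold higher number (0.02 log units; within the scatter) from compound 1 to compound 3 and a 1.1-fold lower number (0.02 log units; within the scatter) from compound 2 to compound 4, 1.1-fold (0.04 log units) apart, within the scatter of two such steps. Among these compounds, both changes therefore carried from one core to the other with no detectable difference, but every step lies within the scatter, so this shows only that neither change measurably moved the number on these two cores and does not show that either would behave the same way on a further core.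

The compounds shown leave open whether any change at these two places can move the number beyond the scatter in this assay. An amine, a carboxylic acid or a longer chain in place of the methyl on the aromatic carbon remains an open case.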